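The source may report more compounds than this note shows. Statements on the series, on what has been measured and on what is new or still open speak of the compounds shown alone.

Measured so far in a physicochemical assay for solubility, measured as thermodynamic solubility, at pH 7.4; on this read-out higher numbers stand for higher solubility and lower numbers for lower solubility:
- compound 1 `O=C1CCOc2nc(C#Cc3ccccc3)ccc21`: 23000 nM
- compound 2 `O=C1NCc2cc(C#Cc3ccccc3)ccc21`: 7000 nM
- compound 3 `O=C1CCOc2cc(OCc3ccc(F)cc3)ccc21`: 5000 nM

Compound 1 stands highest of the three, and its gaps to compound 2 and compound 3 both lie beyond the usual scatter. The unmeasured compound 4 `O=C1CCOc2nc(C#CC3CCCC3)ccc21` keeps the core of compound 1 but carries cyclopentyl in place of phenyl on a triple-bonded carbon. Within the data shown here, no measured pair shows this swap, so the estimate starts from compound 1 at 23000 nM and stays wide. In this assay, no step beyond the scatter is expected, and the estimated change is a 1.3-fold higher number from compound 1 to compound 4 (0.12 log units; within the scatter). Compound 4 is expected at 30000 nM, with an estimated range of 10000 nM to 90000 nM.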

Compound 4, solubility: 23000 nM
For compound 4 the middle estimate is 1.3-fold (0.12 log units) above the measured one; measured number inside the range.
By their numbers in this assay, from the lowest: compounds 3 and 2 (each within the scatter of the next); then compounds 1 and 4 (each within the scatter of the next).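

Placing cyclopentyl in place of phenyl on a triple-bonded carbon gives no change at the digits printed from compound 1 to compound 4 (within the scatter) in this assay. On the core of compound 1, then, a six-membered aromatic ring of carbon only can give way to a five-membered non-aromatic ring of carbon only with the read-out staying within the scatter. Nothing available explains this result.

From the compounds shown here alone, whether the same swap behaves alike on the core of compound 2 remains open. So does the outcome of an amine, a carboxylic acid or a longer chain on that triple-bonded carbon.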